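The compounds below may be only part of what the source reports. "The series", "measured", "known", "first", "only" and "open" are said of these compounds alone.

Values in a physicochemical assay for solubility, with a stated time of 24 h, tested at 30 mg/mL; a lower number here means a less soluble compound, a higher number a more soluble compound:

- compound 1 `CC(=O)N1CC(CC(=O)NO)(NS(=O)(=O)c2ccc(OCc3cc(C)nc4ccccc34)cc2)C1` gives 800000 nM
- compound 2 `CC(=O)N1CC(CC(=O)NO)(NS(=O)(=O)c2ccc(Cc3cc(C)nc4ccccc34)cc2)C1` gives 1900000 nM
- compound 3 `CCc1cc(COc2ccc(S(=O)(=O)NC3(CC(=O)NO)CN(C(C)=O)C3)cc2)c2ccccc2n1` gives 400000 nM

Compound 3 stands level with compound 1 within the scatter, the measured step being a 2.0-fold lower number from compound 1 to compound 3 (0.30 log units; within the scatter). Compound 2 alone stands apart, with a number beyond the scatter of that of compound 3.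

Compound 4 `CC#CCOc1ccc(S(=O)(=O)NC2(CC(=O)NO)CN(C(C)=O)C2)cc1` has not yet been measured. Its change from compound 3 is large: prop-1-yn-1-yl in place of 2-ethylquinolin-4-yl on a saturated chain carbon bound to an oxygen on an aromatic ring. In words, this is prop-1-yn-1-yl in place of 2-ethylquinolin-4-yl on a saturated chain carbon bound to an oxygen on an aromatic ring.

For the measured compounds named here, only one measured step bears on this, and only weakly. It is a 2.0-fold lower number from compound 1 to compound 3 (0.30 log units; within the scatter), a small alteration of the group that now leaves, and it stays within the scatter. Going by the values given here, no measured compound lacks that group, so the data offer no direct guide to its removal. The expectation therefore rests on the spread of the series, from compound 3 (400000 nM) to compound 2 (1900000 nM), and points to a modest rise with wide uncertainty.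

The expected change is a 3.8-fold higher number from compound 3 to compound 4 (0.57 log units; beyond the scatter) in this assay, and it is only loosely held.

For compound 4 the estimated value is 1500000 nM with an expected range from 350000 nM to 7000000 nM in this assay.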

Compound 4, solubility: 1800000 nM
The estimate for compound 4 lay 1.2-fold (0.08 log units) below the measured number, within the range that was stated.
By their numbers in this assay, from the lowest: compounds 3 and 1 (each within the scatter of the next); then compounds 4 and 2 (each within the scatter of the next).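

In this assay, for the compounds shown here, the exchange of 2-ethylquinolin-4-yl for prop-1-yn-1-yl on a saturated chain carbon bound to an oxygen on an aromatic ring gave a 4.5-fold higher number from compound 3 to compound 4 (0.65 log units; beyond the scatter) and is the first step at this position to lie beyond the scatter, where the earlier step had only altered the group slightly and stayed within it. The matching exchange from 2-methylquinolin-4-yl gave a 2.3-fold higher number from compound 1 to compound 4 (0.35 log units; beyond the scatter) and so also lies beyond the scatter, which means that at this position both quinoline-bearing compounds, taken one at a time, give a lower number than the compound carrying the prop-1-yn-1-yl group with its triple bond and no ring. Nothing measured on these compounds accounts for the shift, and the numbers record only its direction and size.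

What remains open is whether the triple bond matters at all, since a saturated propyl chain or a phenyl ring on that same carbon could read either way in this assay on what is shown. Going by these compounds, it is also open whether losing one aromatic ring would be enough, a question that a single pyridin-4-yl group or an amine at this position could address.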